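This account rests on a few compounds, and the source may have more. Where it says the series, first, only, none or still open, it means among the compounds named here.

Values in an ADME assay on the whole organism (Rattus norvegicus, strain Sprague-Dawley) for pharmacokinetics, read by LC-MS, at a dose of 1 mg/kg by the intravenous route; on this read-out higher numbers stand for fast clearance and lower numbers for slow clearance:
- compound 1 `Cc1cccc(Cl)c1CN1CCc2cc(-c3c(C)nc(C)c([C@H](OC(C)(C)C)C(=O)O)c3N3CCC(C)(C)CC3)ccc2C1`: 3.5 mL/min/kg
- compound 2 `Cc1nc(C)c([C@H](OC(C)(C)C)C(=O)O)c(N2CCC(C)(C)CC2)c1-c1ccc2c(c1)CCN(Cc1cccc(F)c1C)C2`: 4 mL/min/kg
- compound 3 `Cc1nc(C)c([C@H](OC(C)(C)C)C(=O)O)c(N2CCC(C)(C)CC2)c1-c1ccc2c(c1)CCN(Cc1ccc(F)cc1F)C2`: 20.1 mL/min/kg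

Compound 3 has the highest number of the three, and its gaps to the other two lie beyond the scatter. Compound 4 `Cc1nc(C)c([C@H](OC(C)(C)C)C(=O)O)c(N2CCC(C)(C)CC2)c1-c1ccc2c(c1)CCN(c1nccc(-c3cnccn3)n1)C2` keeps the shared core and differs from compound 3 by a group of 12 heavy atoms (8 carbon, 4 nitrogen; 2 six-membered aromatic rings with 2 hetero atoms each) in place of a group of 9 heavy atoms (7 carbon, 2 fluorine; one six-membered aromatic ring of carbon only), on an amine nitrogen in a ring; the group that leaves is the 2,4-difluorobenzyl.

The measured steps that bear on this change all alter the group on the same amine nitrogen. They are a 5.7-fold higher number from compound 1 to compound 3 (0.76 log units; beyond the scatter) and a 5.0-fold higher number from compound 2 to compound 3 (0.70 log units; beyond the scatter), both beyond the scatter, while a 1.1-fold higher number from compound 1 to compound 2 (0.06 log units; within the scatter) stays within it. Among the measured compounds shown here, each of these steps keeps a substituted phenyl on a saturated chain carbon, so none tests the entering group directly, and the data offer no measured precedent for it. For the measured compounds named here, the only guide to direction is that both other substituted phenyl groups give lower numbers than compound 3 at 20.1 mL/min/kg. Two comparisons make this a weak basis, so a wide range is warranted.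

The expected change is a 2.9-fold lower number from compound 3 to compound 4 (0.46 log units; beyond the scatter), an estimated modest step toward slower clearance. For compound 4 the estimated value is 7 mL/min/kg, with an expected range of 2.5 mL/min/kg to 22 mL/min/kg.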

Compound 4, clearance: 2.1 mL/min/kg
For compound 4 the middle estimate is 3.3-fold (0.52 log units) above the measured one; the whole stated range lies above it.
By their numbers in this assay, from the lowest: compounds 4, 1 and 2 (each within the scatter of the next); then compound 3.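

In this assay, the amine nitrogen in a ring proves able to carry a group other than a substituted phenyl on a saturated chain carbon, and taking off the 2,4-difluorobenzyl gives a 9.6-fold lower number from compound 3 to compound 4 (0.98 log units; beyond the scatter). Set against the two other substituted phenyl groups, the new group with its 2 six-membered aromatic rings gives a 1.9-fold lower number from compound 2 to compound 4 (0.28 log units; within the scatter) and a 1.7-fold lower number from compound 1 to compound 4 (0.22 log units; within the scatter), so slow clearance at this position is no longer confined to those two groups, and compound 3 alone stands apart among the four. Nothing measured here accounts for this result, whether through the added ring, the nitrogen atoms or the loss of fluorine.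

Going by these compounds, it stays open which part of the entering group carries the result, and whether a single six-membered aromatic ring with 2 hetero atoms, an acetyl or a plain methyl on the same amine nitrogen would fall with compound 4 or with compound 3. Also open, on these data alone, is whether the same group would behave alike if an ester or an amide stood in place of the carboxylic acid on the shared core.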